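The compounds below may be only part of what the source reports. "The series", "measured", "known", "first", "only" and "open" are said of these compounds alone.

Measured compounds:
Compound 1, `CC(C)n1c(=O)n(C(=O)NCCN2CCN(C)CC2)c2cc(F)ccc21`, gives 0.67.
Compound 2, `CN1CCN(CCNC(=O)n2c(=O)[nH]c3ccccc32)CC1`, gives 0.35.

In a functional assay for agonist activity at 5-hydroxytryptamine receptor 4 (Cavia porcellus) (on this read-out lower numbers stand for smaller maximal responses and higher numbers for larger maximal responses), compound 2 stands lowest of the two numbers recorded; its nearest neighbour is compound 1, which gives a number beyond the scatter higher. Within the data shown here, compound 1 differs from compound 2 in more than one place, so no single step between them can be read off; the two values only show that compound 1 sits well above compound 2 in this assay.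

Compound 3, `CN1CCN(CCNC(=O)n2c(=O)n(C)c3ccccc32)CC1`, has not yet been measured. It differs from compound 2 in one place: methyl in place of hydrogen on an aromatic nitrogen.

Among the measured compounds shown here, with no one-place step recorded among the measured compounds, the size of this change can only be estimated. Compound 3 is expected to give 0.5, in the range 0.3 to 0.75, a step of a number 0.15 higher from compound 2 to compound 3 (beyond the scatter) that may reach beyond the scatter.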

Compound 3, intrinsic activity: the largest response reached, as a fraction of the reference agonist's: 0.42
Compound 3: middle estimate off by 0.080, on the high side, within the range that was stated.
By their numbers in this assay, from the lowest: compounds 2 and 3 (each within the scatter of the next); then compound 1.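

In this assay, among these compounds, methyl in place of hydrogen on an aromatic nitrogen gives the first one-place step, a number 0.070 higher from compound 2 to compound 3 (within the scatter) and so this change at this position leaves the maximal response within the usual scatter. The position, on the five-membered aromatic ring and two ring bonds from the ring atom that bears the large group, therefore accepts a single methyl without a readable change in this read-out. Nothing available bears on why this step is as small as it is.

The compounds shown leave open whether a longer chain such as n-propyl, or a ring such as cyclopropyl, on this same nitrogen would give a step beyond the scatter. They also leave open whether methyl in place of hydrogen would read the same on a different core.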